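This account rests on a few compounds, and the source may have more. Where it says the series, first, only, none or still open, it means among the compounds named here.

In a functional assay on HepG2 cells (Homo sapiens) for cytotoxicity, read by XTT assay (on this read-out higher numbers stand for weaker inhibition and lower numbers for stronger inhibition), compound 1 `CC(=O)O[C@H](CC/C(C)=C/[C@@H](O)C/C(C)=C/CCc1ccoc1)[C@]1(C)CCC(=O)O1` gives 500 nM and compound 2 `CC(=O)O[C@H](/C=C(\C)CC[C@@H](O)[C@]1(C)CCC(=O)O1)C/C(C)=C/CCc1ccoc1` gives 2200 nM on the same read-out. Compound 2 therefore holds the higher of the two numbers, and its gap to compound 1 lies beyond the usual scatter. Compound 3 `CC(=O)O[C@H](/C=C(\C)CC[C@@H](OC(C)=O)[C@]1(C)CCC(=O)O1)C/C(C)=C/CCc1ccoc1` departs from compound 2 by one change acetyl in place of hydrogen on an oxygen on a saturated carbon so that hydroxy becomes acetoxy. Within the data shown here, no measured pair shows this change on its own, so the expectation rests on little more than the two numbers in hand and stays loose. In this assay the expected step of a 1.5-fold lower number from compound 2 to compound 3 (0.17 log units; within the scatter) is small and toward a lower number, not clearly beyond the scatter. For compound 3 the estimated value is 1500 nM with an expected range from 500 nM to 4500 nM on this read-out.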

Compound 3, half-maximal inhibitory concentration: 1700 nM
Compound 3: the middle estimate sits 1.1-fold (0.05 log units) below what was measured, and the stated range covers the measured number.
By their numbers in this assay, from the lowest: compound 1; then compounds 3 and 2 (each within the scatter of the next).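

In this assay, putting acetyl in place of hydrogen on the free hydroxy oxygen gives a 1.3-fold lower number from compound 2 to compound 3 (0.11 log units; within the scatter), so at this position the swap from hydroxy to acetoxy makes no readable difference. The same swap on the other oxygen gives a 3.4-fold higher number from compound 1 to compound 3 (0.53 log units; beyond the scatter), which lies beyond the scatter. The effect of this change therefore depends on which of the two oxygens carries it, a contrast that rests on these two steps alone, and nothing available accounts for it.

The compounds shown leave open whether a longer acyl chain such as butanoyl, or a methyl ether, on either oxygen would follow the same contrast. They also leave open how a compound with free hydroxy groups on both oxygens would stand.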